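Isobutoxy in place of benzyloxy on the chromone series

A few compounds are considered here, and "the series" means these few. Any claim that something is new, unique, unknown or untested is made for them only; others in the source may bear on it.

Three members of the series have been run in a functional assay on MDA-MB-231 cells (Homo sapiens) for antiproliferative activity, read by XTT assay; on this read-out higher numbers stand for weaker inhibition and lower numbers for stronger inhibition. Compound 1 `Cc1ccc2c(=O)c(Cc3coc4cccc(OCC5CCCCC5)c4c3=O)coc2c1` gives 3320 nM. Compound 3 `O=C1c2c(OCC3CCCCC3)cccc2OCC1Cc1coc2ccccc2c1=O` gives 9110 nM. For compound 2 `O=c1c(Cc2coc3cccc(OCc4ccccc4)c3c2=O)coc2ccccc12` the assay reports only a limit, > 10000 nM, so no number is known for it. This is the limit of > 10000 nM in this assay, at which 1 of the 3 values shown sits. On the numbers shown compound 2 therefore stands at the weak end of the set, without a figure that would let it be ordered against compound 1 or compound 3, and no step between two measured compounds differing in one place is available.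

Compound 4 `CC(C)COc1cccc2occ(Cc3coc4ccccc4c3=O)c(=O)c12` is the next entry and differs from compound 2 in one place: isopropyl in place of phenyl on a saturated chain carbon bound to an oxygen on an aromatic ring. The ether chain remains, the ring at its end does not. Compound 1 also lacks the benzyl group but differs from compound 2 in more than one place. In this assay compound 1 gives 3320 nM. Going by the values given here, with no measured step for the change itself, only an expectation can be given. In this assay the expected step is an at least 1.6-fold lower number from compound 2 to compound 4 (0.22 log units; that floor lies within the scatter), toward stronger inhibition, though starting from a limit the gain may remain within the scatter. Compound 4 is expected to give 6000 nM in this assay, with a range from 2000 nM to 15000 nM.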

Compound 4, half-maximal inhibitory concentration: > 10000 nM
Compound 4 ended at the assay's limit (the forecaster's own chance of this, stated with the estimate: 35%); at least 1.6-fold (0.22 log units) between middle value and limit.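

In this assay compound 4 gives > 10000 nM, which is a limit and not a number. Compound 2 also stands at a limit, so no step can be read between compound 2 and compound 4: the limit of > 10000 nM in this assay, at which 2 of the 4 values shown sit.

Left open is how isobutoxy and benzyloxy on the shared core rank against each other in this assay.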